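This account rests on a few compounds, and the source may have more. Where it says the series, first, only, none or still open, it means among the compounds named here.

In an ADME assay on C8166 cells (Homo sapiens) for cytotoxicity, read by MTT assay (a lower number here means that less compound is tolerated, a higher number that more compound is tolerated), compound 1 `O=C(O)c1cn(-c2ccccc2)c2ccc(Cc3cccc(Cl)c3F)c(O)c2c1=O` gives 388000 nM as the highest number, compound 2 `Cc1cccc(-n2cc(C(=O)O)c(=O)c3c(O)c(Cc4cccc(Cl)c4F)ccc32)c1` gives 71600 nM and compound 3 `O=C(O)c1cn(-c2ccc(Br)cc2)c2ccc(Cc3cccc(Cl)c3F)c(O)c2c1=O` gives 85000 nM on the same read-out. Compound 3 lies within the scatter of compound 2 (a 1.2-fold higher number from compound 2 to compound 3 (0.07 log units; within the scatter)) and clearly under compound 1 (a 4.6-fold lower number from compound 1 to compound 3 (0.66 log units; beyond the scatter)). Among the compounds with values here, compound 4 `O=C(O)c1cn(Cc2ccccc2)c2ccc(Cc3cccc(Cl)c3F)c(O)c2c1=O` has benzyl in place of 4-bromophenyl on an aromatic nitrogen, a change no measured step covers directly. Compound 1 carries neither methyl nor bromo and stands apart from compound 2 as well (a 5.4-fold lower number from compound 1 to compound 2 (0.73 log units; beyond the scatter)); compound 4 also carries neither. A modest step to a higher number is therefore expected in this assay (a 2.2-fold higher number from compound 3 to compound 4 (0.35 log units; beyond the scatter)). For compound 4 the estimate is 190000 nM with an expected range of 55000 nM to 500000 nM for now.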

Compound 4, half-maximal cytotoxic concentration: 20300 nM
Estimate against measurement, compound 4: 9.4-fold (0.97 log units) above, outside the stated range (below it).
By their numbers in this assay, from the lowest: compound 4; then compounds 2 and 3 (each within the scatter of the next); then compound 1.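

Benzyl on the aromatic nitrogen gives the lowest number of the four compounds in this assay (a 4.2-fold lower number from compound 3 to compound 4 (0.62 log units; beyond the scatter)) and (a 3.5-fold lower number from compound 2 to compound 4 (0.55 log units; beyond the scatter)). The largest step in the series is the one from phenyl to benzyl at this position (a 19-fold lower number from compound 1 to compound 4 (1.28 log units; beyond the scatter)), so less compound is tolerated with benzyl than with phenyl, 3-methylphenyl or 4-bromophenyl. No evidence is available to explain this result.

Still open, from the compounds shown here alone, is whether a longer chain on this nitrogen, such as phenethyl, would extend the trend. Also open, going by these compounds, is how an amine or a bromo on the ring of benzyl would shift the number.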